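From 4-Chlorophenyl to Ethoxy on a Carbonyl Carbon

A few compounds are considered here, and "the series" means these few. Any claim that something is new, unique, unknown or untested is made for them only; others in the source may bear on it.

Compound 1 `Cn1cncc1CN1CC(N(CC2CCN(C(=O)c3ccc(Cl)cc3)CC2)S(=O)(=O)c2ccccn2)Cc2cc(C#N)ccc21`, compound 2 `Cn1cncc1CN1CC(N(CC2CCN(C(=O)C3CCCC3)CC2)S(=O)(=O)c2ccccn2)Cc2cc(C#N)ccc21` and compound 3 `Cn1cncc1CN1CC(N(CC2CCN(C(=O)NC(C)(C)C)CC2)S(=O)(=O)c2ccccn2)Cc2cc(C#N)ccc21` share one core and differ only in the group attached to a carbonyl carbon. In an ADME assay on Caco-2 cells (Homo sapiens) for permeability, in the apical to basolateral direction (on this read-out higher numbers stand for higher permeability and lower numbers for lower permeability), compound 1 gives 0.5 10^-6 cm/s, compound 2 gives 0.5 10^-6 cm/s and compound 3 gives 0.6 10^-6 cm/s. The three numbers sit close together: no change at the digits printed from compound 1 to compound 2 (within the scatter), a 1.2-fold higher number from compound 1 to compound 3 (0.08 log units; within the scatter) and a 1.2-fold higher number from compound 2 to compound 3 (0.08 log units; within the scatter), so compound 1 cannot be told apart from either neighbour on this assay.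

Compound 4 `CCOC(=O)N1CCC(CN(C2Cc3cc(C#N)ccc3N(Cc3cncn3C)C2)S(=O)(=O)c2ccccn2)CC1` is reached from compound 1 by the change (ethoxy in place of 4-chlorophenyl on a carbonyl carbon). Each measured step also swapped the group on this same carbonyl carbon, and none of them moved the read-out beyond the scatter. Among the measured compounds shown here, no measured step introduces ethoxy, so there is no direct precedent for it, only the observation that this position has so far tolerated three rather different groups without a visible shift.

Compound 4 is therefore expected to stay close to compound 1, with an expected step of a 1.2-fold higher number from compound 1 to compound 4 (0.08 log units; within the scatter). The estimate for compound 4 in this assay is 0.6 10^-6 cm/s, with a range from 0.3 10^-6 cm/s to 1.2 10^-6 cm/s.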

Compound 4, apparent permeability: 2.6 10^-6 cm/s
Compound 4: the middle estimate sits 4.3-fold (0.64 log units) below what was measured; the whole stated range lies below it.
By their numbers in this assay, from the lowest: compounds 1, 2 and 3 (each within the scatter of the next); then compound 4.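

The read-out at this position is not indifferent to the group on the carbonyl carbon, as the three earlier compounds alone might have suggested. In this assay, ethoxy stands clearly apart from 4-chlorophenyl (a 5.2-fold higher number from compound 1 to compound 4 (0.72 log units; beyond the scatter)), from cyclopentyl (a 5.2-fold higher number from compound 2 to compound 4 (0.72 log units; beyond the scatter)) and from (tert-butyl)amino (a 4.3-fold higher number from compound 3 to compound 4 (0.64 log units; beyond the scatter)), while those three groups cannot be told apart from one another. Nothing available explains why ethoxy behaves differently.

Among the compounds shown here, with ethoxy as the only group of its kind here, it remains open whether methoxy, propoxy or tert-butoxy on the same carbonyl carbon would give a similar number. From the compounds shown here alone, it also remains open whether a smaller group such as methyl would do the same, which would tie the result to size rather than to ethoxy itself.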